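This account rests on a few compounds, and the source may have more. Where it says the series, first, only, none or still open, it means among the compounds named here.

Compound 1 `O=C(CN(c1nc(Cl)nc2[nH]cnc12)C1CC1)N[C@@H](CO)C(=O)OCc1ccccc1` gives 27.9% in a functional assay on the whole organism (Tail, strain ICR) with Mus musculus as the target, in the tail flick test, with a stated time of 150 min, at a dose of 25 umol/kg by the oral route; on this read-out higher numbers stand for a stronger effect at the one dose given and lower numbers for a weaker effect. Compound 2 `O=C(CN(c1nc(Cl)nc2[nH]cnc12)C1CC1)N[C@@H](CO)C(=O)O` carries hydrogen in place of benzyl on an oxygen next to a carbonyl group and gives 18.8%; the step of a number 9.1 percentage points lower from compound 1 to compound 2 (within the scatter). Compound 3 `CC(C)C[C@H](NC(=O)CN(c1nc(Cl)nc2[nH]cnc12)C1CC1)C(=O)OCc1ccccc1` differs from compound 1 in its core by isopropyl in place of hydroxy on a saturated chain carbon, two bonds along the chain from an amide-type nitrogen and a carbonyl carbon; in this assay compound 3 gives 5.26%; the step of a number 22.6 percentage points lower from compound 1 to compound 3 (beyond the scatter). Compound 4 `CC(C)C[C@H](NC(=O)CN(c1nc(Cl)nc2[nH]cnc12)C1CC1)C(=O)O` has not been measured; it is compound 3 with hydrogen in place of benzyl on an oxygen next to a carbonyl group, the same change as that from compound 1 to compound 2, on a core that differs as just told. Among the measured compounds shown here, only that one earlier step, a number 9.1 percentage points lower from compound 1 to compound 2 (within the scatter), is there to rest on, and it lay within the scatter; compound 3 already stands lowest. Compound 4 is therefore expected to move by about a number 2.3 percentage points lower from compound 3 to compound 4 (within the scatter), and its estimated value is 3%, between -8% and 15%.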

Compound 4, a percentage reported as activity, at one dose (the size of the read-out at that dose, not a potency): 9.13%
Estimate against measurement, compound 4: 6.1 percentage points below, within the range that was stated.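

In this assay, hydrogen in place of benzyl on an oxygen next to a carbonyl group gives a number 3.9 percentage points higher from compound 3 to compound 4 (within the scatter), and this step cannot be told apart from the earlier one: the same change on two cores in this assay, a number 9.1 percentage points lower (within the scatter) from compound 1 to compound 2 and a number 3.9 percentage points higher (within the scatter) from compound 3 to compound 4, 13 percentage points apart, within the scatter of two such steps

Isopropyl in place of hydroxy gives a number 9.7 percentage points lower from compound 2 to compound 4 (within the scatter), and this step likewise cannot be told apart from its earlier counterpart: the same change on two cores in this assay, a number 22.6 percentage points lower (beyond the scatter) from compound 1 to compound 3 and a number 9.7 percentage points lower (within the scatter) from compound 2 to compound 4, 13 percentage points apart, within the scatter of two such steps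

Among the compounds shown here, both changes are therefore compatible with carrying over between the two cores, but each rests on only two steps, and this shows no more than that no difference could be detected, not that the changes act alike on both cores.

On these data alone, whether a methyl ester or an ethyl ester would fall in line with the benzyl ester and the carboxylic acid remains open. So does whether a longer chain or an amine on the side chain would follow the hydroxy and isopropyl compounds.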